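Hydroxy removal: 4-hydroxy-2,3-dimethylphenyl to 2,3-dimethylphenyl

The source may hold more compounds than are shown below. What is called first, only, known or untested is meant among the compounds shown, and "the series" means these compounds.

In a functional assay on KBVIN cells (Homo sapiens) for antiproliferative activity, read by sulforhodamine B assay, with a stated time of 3 days (on this read-out higher numbers stand for an effect only at larger amounts of compound and lower numbers for an effect already at smaller amounts), compound 1 `CCC1=C(O)c2c(oc(-c3ccc(F)cc3)cc2=O)C(CC)(CC)C1=O` gives 1.85 uM and compound 2 `CCC1=C(O)c2c(oc(-c3ccc(O)c(C)c3C)cc2=O)C(CC)(CC)C1=O` gives 2.75 uM on the shared core. Within the data shown here, the only measured step is a 1.5-fold higher number from compound 1 to compound 2 (0.17 log units; within the scatter) and it exchanges 4-fluorophenyl for 4-hydroxy-2,3-dimethylphenyl, so compound 2 stands level with compound 1 on the numbers available.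

Compound 3 `CCC1=C(O)c2c(oc(-c3cccc(C)c3C)cc2=O)C(CC)(CC)C1=O` is the next case, defined by the difference hydrogen in place of hydroxy on an aromatic carbon in which hydrogen takes the place of hydroxy on an aromatic carbon, para to a large group. Among the measured compounds shown here, no measured pair isolates this hydroxy group, so the evidence is indirect. The closest guide is compound 2, reached by a 1.5-fold higher number from compound 1 to compound 2 (0.17 log units; within the scatter) as a replacement of the whole aryl group that stayed inside the scatter. On these data alone, on that single step, no change beyond the scatter is expected in this assay and the direction remains open. The estimate means a 1.1-fold lower number from compound 2 to compound 3 (0.04 log units; within the scatter) and that expected step is no real shift. For compound 3 the estimated value is 2.5 uM with an expected range from 1.2 uM to 5.5 uM on this read-out.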

Compound 3, concentration for half-maximal effect: 0.85 uM
The estimate for compound 3 lay 2.9-fold (0.47 log units) above the measured number; measured number below the stated range.
By their numbers in this assay, from the lowest: compound 3; then compounds 1 and 2 (each within the scatter of the next).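

Hydrogen in place of hydroxy on this aromatic carbon, para to a large group, is the first change in the series that isolates a single substituent, and in this assay it gives a 3.2-fold lower number from compound 2 to compound 3 (0.51 log units; beyond the scatter) as a modest shift beyond the scatter. The exchange of the whole aryl group between compound 1 and compound 2 had stayed within the scatter, whereas the 2,3-dimethylphenyl group of compound 3 gives a 2.2-fold lower number from compound 1 to compound 3 (0.34 log units; beyond the scatter) and so separates from 4-fluorophenyl once the hydroxy group is gone. No measurement at hand accounts for either shift.

On these data alone, the contribution of the two methyl groups stays open: both compound 2 and compound 3 carry them, and the step from compound 1 changes them together with the fluorine. Among these compounds, it is also open whether a methoxy group, an amine or a chlorine on the same carbon would read like hydroxy in compound 2 or like hydrogen in compound 3, so the result describes only this one pair of groups at this position on the shared core.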